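This account rests on a few compounds, and the source may have more. Where it says the series, first, only, none or still open, it means among the compounds named here.

Two compounds in this series have been examined for how much they harm cells, and a third awaits its turn. Compound 1 `N#CCN1C(=O)N(Cc2cccc(F)c2)S(=O)(=O)n2cccc21` carries a short nitrile-bearing chain on the shared core, and in an ADME assay on MT4 cells (Homo sapiens) for cytotoxicity, read by MTT assay, with a stated time of 5 days (on this read-out higher numbers stand for lower toxicity in this test and lower numbers for higher toxicity in this test), compound 1 gives 172000 nM. Compound 2 `O=C1N(Cc2ccc(Cl)cc2Cl)c2cccn2S(=O)(=O)N1Cc1cccc(Cl)c1` replaces that chain with a halogenated benzyl group and changes the other benzyl group as well. In this assay compound 2 is reported only as > 251000 nM, which is a limit of the test rather than a number. Compound 2 therefore stands at the limit of > 251000 nM in this assay, at which 1 of the 2 values shown sits, and its true value is not known beyond that. Compound 3 `O=C1N(Cc2ccc(Cl)cc2Cl)c2cccn2S(=O)(=O)N1Cc1cccc(F)c1` differs from compound 2 in a single place: fluoro in place of chloro on an aromatic carbon. For the measured compounds named here, no step between two measured compounds of this kind is available, so there is nothing to size the change against directly. The swap is expected to leave the result close to where compound 2 sits, and the step of a number no higher from compound 2 to compound 3 (the limit leaves the size open) is estimated to stay within the usual scatter. Compound 3 is expected to give about 250000 nM, within a range of 120000 nM to 450000 nM, and may well come back only as a limit again.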

Compound 3, half-maximal cytotoxic concentration: > 249000 nM
Compound 3 was reported as a limit; the forecaster's own chance of this, stated with the estimate: 60%; the middle value lies beyond the limit too.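

In this assay compound 3 is reported as > 249000 nM, which is a limit and not a number. With fluoro in place of chloro on the benzyl group, the result remains a limit, as it was for compound 2, so this position has now given no exact number with either halogen, and the step between these two compounds cannot be read. With the 3-fluorobenzyl group kept, 2,4-dichlorophenyl in place of cyano on the chain gives an at least 1.4-fold higher number from compound 1 to compound 3 (0.16 log units; that floor lies within the scatter), so this pair offers only a floor, and the real gap could be small or much larger.

As far as these compounds go, how far compound 2 and compound 3 lie past their limits stays open, which means chloro and fluoro cannot be ranked in this test. Also open, from the compounds shown here alone, is whether another group at this place on the aromatic ring, such as an amine or a carboxylic acid, would bring the read-out down to a number that can be measured exactly.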